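Benzylsulfanyl Analogue in the Maximal Electroshock Test

The source may hold more compounds than are shown below. What is called first, only, known or untested is meant among the compounds shown, and "the series" means these compounds.

Compound 1, `CSc1nnc(-c2ccccc2OCc2ccccc2)o1`, in a functional assay on the whole organism with Mus musculus as the target, in the maximal electroshock model; a higher number here means that more compound is needed for the effect, a lower number that less compound is needed: > 100 mg/kg, a limit of the assay.
Compound 2, `CCSc1nnc(-c2ccccc2OCc2ccccc2)o1`, in this assay: > 100 mg/kg, again a limit of the assay.

Among the measured compounds shown here, compound 2 therefore stands at a limit, not at a measured number, and the only recorded step, a step that the two limits leave unreadable from compound 1 to compound 2, cannot be read in size or direction. Both values sit at the limit of > 100 mg/kg in this assay, at which 2 of the 2 values shown sit.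

Compound 3, `c1ccc(COc2ccccc2-c2nnc(SCc3ccccc3)o2)cc1`, differs from compound 2 by phenyl in place of methyl on a saturated chain carbon bound to a sulfur. For the measured compounds named here, the single measured step that bears on this change is the one from compound 1 to compound 2, and since it is unreadable, no magnitude can be carried over to this assay. What the two measured compounds show is that the shared core, with either methylsulfanyl or ethylsulfanyl, has not produced a readable dose below the limit.

On that basis the step from compound 2 to compound 3 is expected to be a number no higher from compound 2 to compound 3 (the limit leaves the size open), that is, none readable beyond the scatter. Compound 3 is estimated at 100 mg/kg, with a range from 30 mg/kg to 300 mg/kg, and the most likely outcome for compound 3 is that the assay once more reports only a limit.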

Compound 3, dose for half-maximal effect: > 100 mg/kg
Compound 3: only a limit was reported; the forecaster's own chance of this, stated with the estimate: 65%; the middle value lies on the limit itself.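

In this assay compound 3 gives > 100 mg/kg, again a limit of the assay. No step among compound 1, compound 2 and compound 3 can be read, in size or in direction: the limit of > 100 mg/kg in this assay, at which 3 of the 3 values shown sit.

The compounds shown leave open whether these three differ at all in this assay, and what dose any of them would need for the effect.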